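A few compounds are considered here, and "the series" means these few. Any claim that something is new, unique, unknown or untested is made for them only; others in the source may bear on it.

Measured compounds:

- compound 1, `CNC(=O)c1cccc(C#Cc2ccccc2Nc2ncnc3ccc(Cl)nc23)c1`: in an assay on isolated protein for inhibition of MAP kinase-interacting serine/threonine-protein kinase 2 (Homo sapiens), read by HTRF, in the presence of a further agent that is not named here (on this read-out lower numbers stand for stronger inhibition and higher numbers for weaker inhibition), compound 1 gives 4900 nM
- compound 2, `CCCNC(=O)c1cccc(C#Cc2ccccc2Nc2ncnc3ccc(Cl)nc23)c1`: in this assay compound 2 gives 3900 nM
- compound 3, `CCCNC(=O)c1oc2ccc(Nc3ncnc4ccc(Cl)nc34)cc2c1C`: in this assay compound 3 gives 1900 nM

Compounds 1 and 2 share one core and differ only at the amide substituent, (hydrogen in place of ethyl on a saturated chain carbon bound to an amide-type nitrogen). The step in this assay is a 1.3-fold higher number from compound 2 to compound 1 (0.10 log units; within the scatter), so the two values cannot be ordered against each other. Compound 3 carries a different core; how the two cores differ is not broken down here. Its value is the lowest of the three, and the gaps to compound 2 and to compound 1 both lie beyond the scatter.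

Compound 4, `CNC(=O)c1oc2ccc(Nc3ncnc4ccc(Cl)nc34)cc2c1C`, is not yet measured. It stands to compound 3 as compound 1 stands to compound 2: hydrogen in place of ethyl on a saturated chain carbon bound to an amide-type nitrogen. The place of the change is described in the same words in both pairs, so this is the same change made on the core of compound 3 instead of the core of compound 2.

Among the measured compounds shown here, the only guide is the measured pair. Because a 1.3-fold higher number from compound 2 to compound 1 (0.10 log units; within the scatter) lies within the scatter, the expected step in this assay is a 1.3-fold higher number from compound 3 to compound 4 (0.12 log units; within the scatter), that is, a number close to that of compound 3 and likely no worse than the scatter allows. Whether a different core carries the change differently cannot be judged from one pair. For compound 4 the estimate in this assay is 2500 nM, with an expected range from 1200 nM to 5000 nM.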

Compound 4, half-maximal inhibitory concentration: 2500 nM
Compound 4: the middle estimate sits on the measured number at the digits printed; low and high end bracket the measured number.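

In this assay, going from propylcarbamoyl to methylcarbamoyl on the core of the furthest-reaching pair gives a 1.3-fold higher number from compound 3 to compound 4 (0.12 log units; within the scatter), so the two values in this pair cannot be ordered against each other. Set beside the same change on the other core, the step shows no readable dependence on which of the two cores carries it: the same change on two cores in this assay, a 1.3-fold higher number (0.10 log units; within the scatter) from compound 2 to compound 1 and a 1.3-fold higher number (0.12 log units; within the scatter) from compound 3 to compound 4, 1.0-fold (0.02 log units) apart, within the scatter of two such steps. This agreement holds only for a change that gives no readable step on either core, so it shows that swapping propyl for methyl at this amide makes little difference on both, but not that a change with a clear effect would carry from one core to the other to the same extent.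

Still open, on these data alone, is whether a longer chain such as butyl, a chain ending in an amine, a chain ending in a carboxylic acid, or the amide with hydrogen alone on its nitrogen would give a step beyond the scatter on either core, and whether such a step would then match between the two. With only propyl and methyl compared at this amide, and in only this one assay, how far the tolerance at this place extends remains undefined.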